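Swapping a Furan for an Imidazole on a Shared Core

The compounds below may be only part of what the source reports. "The series", "measured", "known", "first", "only" and "open" are said of these compounds alone.

Compound 2 `Cc1nc2sc(-c3ccco3)nc2c(=O)[nH]1` and compound 1 `Cc1nc2sc(-c3cccc(Cl)c3)nc2c(=O)[nH]1` share the same core and differ only in the ring attached to it. In an assay on CHO cells for displacement of a labelled ligand from adenosine receptor A1 (Homo sapiens), read by scintillation counting, with a stated time of 120 min, tested at 1 uM (on this read-out lower numbers stand for less inhibition and higher numbers for more inhibition at the one concentration tested (going by the name of the read-out)), compound 2 gives 37%, the higher of the two numbers, while compound 1 gives 24%, a gap beyond the usual scatter. Compound 3 `Cc1nc2sc(-n3ccnc3)nc2c(=O)[nH]1` carries the change (1H-imidazol-1-yl in place of furan-2-yl on an aromatic carbon). Among the measured compounds shown here, no measured pair shows what this swap does, so the expectation rests on compound 2 alone. A small fall is expected, a step of a number 12 percentage points lower from compound 2 to compound 3 (beyond the scatter) in this assay. Compound 3 is estimated at 25%, within a range from 8% to 45%.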

Compound 3, a percentage reported as inhibition, at one concentration (the size of the read-out at that concentration, not a potency): 1%
For compound 3 the middle estimate is 24 percentage points above the measured one, and the stated range ends above it.
By their numbers in this assay, from the lowest: compound 3; then compound 1; then compound 2.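

Replacing furan-2-yl with 1H-imidazol-1-yl at this position, next to the ring nitrogen and next to the ring sulfur, gives (a number 36 percentage points lower from compound 2 to compound 3 (beyond the scatter)) in this assay. Both groups are five-membered aromatic rings of the same heavy-atom count, so inhibition at this position depends strongly on which ring is present, not only on its size. Nothing available explains this fall.

As far as these compounds go, whether the extra ring nitrogen or the attachment through nitrogen matters more remains open. So does the effect of a thiophen-2-yl ring or an amine here.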